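Trimming a Five-Atom Group Down to Dimethylamino

A few compounds are considered here, and "the series" means these few. Any claim that something is new, unique, unknown or untested is made for them only; others in the source may bear on it.

Compound 1 `Cc1ccn2c(C)c(C)nc2c1OCc1ccccc1`: 92%
Compound 2 `Cc1nc2c(OCc3ccccc3)cccn2c1/N=C/N(C)C`: 64%

In a functional assay on the whole organism with Rattus norvegicus as the target, at a dose of 40 mg/kg by the intraperitoneal route (on this read-out higher numbers stand for more inhibition at the one dose given (going by the name of the read-out) and lower numbers for less inhibition), compound 1 gives 92% while compound 2 gives 64%. Compound 2 stands lowest of the two numbers, and compound 1 lies beyond the scatter above it. Compound 3 `Cc1nc2c(OCc3ccccc3)cccn2c1N(C)C` is not yet measured; it differs from compound 2 by a group of 3 heavy atoms (2 carbon, 1 nitrogen; no ring) in place of a group of 5 heavy atoms (3 carbon, 2 nitrogen; no ring), on an aromatic carbon. Going by the values given here, no measured pair shares this change, so the step is expected to be a modest rise, because the methyl-bearing compound 1 gives 92% in this assay. Compound 3 is expected at 76%, with a range from 52% to 94%. The step from compound 2 to compound 3 is estimated at a number 12 percentage points higher from compound 2 to compound 3 (beyond the scatter).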

Compound 3, a percentage reported as inhibition, in the whole organism at one dose (the size of the read-out at that dose, not a potency): 76%
Beside the measured number, compound 3's estimate shows no gap at the digits printed; low and high end bracket the measured number.
By their numbers in this assay, from the lowest: compound 2; then compound 3; then compound 1.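

At this position, on an aromatic carbon of the five-membered ring, the shared core accepts a change of group: dimethylamino in place of the larger group with its double bond gives a number 12 percentage points higher from compound 2 to compound 3 (beyond the scatter) in this assay. Both groups have the same count of hydrogen-bond acceptors and donors, so those counts do not separate them. No measurement here gives a reason for the step.

A single step sets no trend. From the compounds shown here alone, whether a primary amine, a diethylamino group or a longer chain would read higher or lower at this position stays open.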